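The source may report more compounds than this note shows. Statements on the series, on what has been measured and on what is new or still open speak of the compounds shown alone.

In an ADME assay on MDBK cells (Bos taurus) for cytotoxicity, read by MTT assay, with a stated time of 96 h (a higher number here means that more compound is tolerated, a lower number that less compound is tolerated), compound 1 `COc1ccc(/N=N/N2CCCC2)cc1` gives 60000 nM. Compound 2 `Clc1ccc(/N=N/N2CCCC2)cc1` gives only a limit of the assay, > 100000 nM, and not a number. Compound 3 `Brc1ccc(/N=N/N2CCCC2)cc1` differs from compound 2 in one place, with bromo in place of chloro on an aromatic carbon. Going by the values given here, the only measured step, with chloro in place of methoxy, is an at least 1.6-fold higher number from compound 1 to compound 2 (0.22 log units; that floor lies within the scatter), and it offers no ground for expecting a change beyond the scatter. The expected step is an at least 1.1-fold lower number from compound 2 to compound 3 (0.07 log units; that floor lies within the scatter). For compound 3, the estimated value in this assay is 85000 nM, with an expected range of 40000 nM to 150000 nM.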

Compound 3, half-maximal cytotoxic concentration: > 100000 nM
Compound 3: no number, only a limit; the forecaster's own chance of this, stated with the estimate: 50%; middle value at least 1.1-fold (0.07 log units) away from the limit.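

Compound 3 shows that a second group on this aromatic carbon, bromo as well as chloro, gives a limit of this assay and not a number. Against methoxy, bromo gives an at least 1.6-fold higher number from compound 1 to compound 3 (0.22 log units; that floor lies within the scatter), the same floor as chloro. The step between chloro and bromo cannot be read, because both compounds end at the same limit: the limit of > 100000 nM in this assay, at which 2 of the 3 values shown sit.

On these data alone, how far compound 2 and compound 3 truly lie past that limit stays open. Also open, as far as these compounds go, is whether an amine or a carboxylic acid on this carbon would give a number, and how that number would compare with compound 1.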